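The source may report more compounds than this note shows. Statements on the series, on what has been measured and on what is new or still open speak of the compounds shown alone.

Compound 1 `O=C(c1ccccc1)N1CCn2nc(-c3cccnc3)cc2C1` carries a pyridin-3-yl on the shared core. In a functional assay on HEK293 cells for negative allosteric modulation of metabotropic glutamate receptor 5 (Homo sapiens), read by calcium flux, with a stated time of 20 min (on this read-out higher numbers stand for weaker inhibition and lower numbers for stronger inhibition), compound 1 gives > 10000 nM, which is a limit of the assay and not a number. Compound 1 therefore sits at the limit of > 10000 nM in this assay, at which 1 of the 3 values shown sits, and its place among the others cannot be fixed. Compound 4 `Cc1ccnc(-c2cc3n(n2)CCN(C(=O)c2ccccc2)C3)c1` differs from compound 1 by 4-methylpyridin-2-yl in place of pyridin-3-yl on an aromatic carbon. Going by the values given here, the only measured step, a 35-fold lower number from compound 2 to compound 3 (1.54 log units; beyond the scatter), joins compound 2 `O=C(c1ccc(Cl)cc1)N1CCn2nc(-c3ccccn3)cc2C1` and compound 3 `O=C(c1cc(Cl)cc(Cl)c1)N1CCn2nc(-c3ccccn3)cc2C1`: in this assay compound 2 gives 9470 nM and compound 3 gives 270 nM. That step alters the group on a carbonyl carbon, not the ring exchanged here, so it does not bear on the change from compound 1 to compound 4. Compound 4 is expected to stay near the limit, with a number no higher from compound 1 to compound 4 (the limit leaves the size open) estimated as no step beyond the scatter. The estimate for compound 4 is 10000 nM, between 2500 nM and 40000 nM.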

Compound 4, half-maximal inhibitory concentration: 451 nM
Estimate against measurement, compound 4: 22-fold (1.35 log units) above; the measured number lies below the stated range.
By their numbers in this assay, from the lowest: compounds 3 and 4 (each within the scatter of the next); then compound 2. At a limit, above all of these: compound 1.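

With the group on the carbonyl carbon left unchanged, the exchange of rings on the aromatic carbon gives an at least 22-fold lower number from compound 1 to compound 4 (1.34 log units; beyond the scatter). This position, untouched by the earlier step, therefore also moves the number in this assay. The full size of the step stays open because compound 1 stands at a limit: the limit of > 10000 nM in this assay, at which 1 of the 4 values shown sits.

The exchange both shifts the ring nitrogen and adds a methyl, and the compounds shown do not separate the two. As far as these compounds go, whether an amine or a longer chain in place of that methyl would serve as well also stays open.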